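The compounds below may be only part of what the source reports. "The series", "measured", "known", "first", "only" and "open" are said of these compounds alone.

In a functional assay on MCF7 cells (Homo sapiens) for antiproliferative activity, read by CCK-8 assay, with a stated time of 48 h (on this read-out lower numbers stand for stronger inhibition and higher numbers for weaker inhibition), compound 1 (`C=CC(=O)NCCOc1ccc(Oc2c(-c3ccc(F)cc3)sc3cc(O)ccc23)cc1`) gives 23000 nM and compound 2 (`C/C=C/C(=O)N1CC(Oc2ccc(Oc3c(-c4ccc(F)cc4)sc4cc(O)ccc34)cc2)C1`) gives 28000 nM. Compound 1 therefore has one measured neighbour, and the two values lie within the scatter of each other, so no order can be drawn between them. Within the data shown here, the only measured step, a 1.2-fold higher number from compound 1 to compound 2 (0.09 log units; within the scatter), puts 1-((prop-1-en-1-yl)carbonyl)azetidin-3-yl in place of 2-((vinylcarbonyl)amino)ethyl on an oxygen on an aromatic ring.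

Compound 3 (`O=C(/C=C/CNCCOc1ccc(Oc2c(-c3ccc(F)cc3)sc3cc(O)ccc23)cc1)N1CCCCC1`) carries a different change: 3-((piperidin-1-yl)carbonyl)prop-2-en-1-yl in place of vinylcarbonyl on an amine nitrogen, (3-((piperidin-1-yl)carbonyl)prop-2-en-1-yl in place of vinylcarbonyl on an amine nitrogen). The measured step touches the same side chain but does not cover this replacement, so it offers only weak guidance. Among the measured compounds shown here, its small size gives no sign of a large shift in this assay, yet no measurement yet tests the entering group. A modest move toward a lower number is expected, and no change remains possible. The expected step is a 1.9-fold lower number from compound 1 to compound 3 (0.28 log units; within the scatter), an estimate with wide uncertainty. For compound 3 the estimated value is 12000 nM, with an expected range of 3000 nM to 40000 nM.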

Compound 3, half-maximal inhibitory concentration: 16400 nM
For compound 3 the middle estimate is 1.4-fold (0.14 log units) below the measured one, within the range that was stated.
By their numbers in this assay, from the lowest: compounds 3, 1 and 2 (each within the scatter of the next).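

In this assay the step at the amine nitrogen, with 3-((piperidin-1-yl)carbonyl)prop-2-en-1-yl in place of vinylcarbonyl, is a 1.4-fold lower number from compound 1 to compound 3 (0.15 log units; within the scatter), so this first direct change at that nitrogen gives no readable shift. The entering group has 11 heavy atoms against 4 in the group that leaves and adds one six-membered non-aromatic ring with 1 hetero atom, while the counts of double bonds outside aromatic rings and of hydrogen-bond acceptors stay the same; in this series, that growth in size comes with a number that stays within the scatter of compound 1. The data give no measured property that would account for this result.

Among these compounds, with only this one step at the amine nitrogen, it remains open whether the flat reading extends to other groups there, such as a morpholine ring in place of the piperidine ring or a free carboxylic acid in place of the piperidine amide. Also open, on these data alone, is whether a shorter chain or a longer chain on the oxygen on the aromatic ring would carry any of these values beyond the scatter of compound 1.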